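The source may hold more compounds than are shown below. What is called first, only, known or untested is meant among the compounds shown, and "the series" means these compounds.

Measured compounds in an ADME assay on MT4 cells (Homo sapiens) for cytotoxicity, read by MTT assay, with a stated time of 4 days; a higher number here means that more compound is tolerated, a lower number that less compound is tolerated:

Compound 1 `CC(=O)Nc1ccc2oc(-c3ccccc3)cc(=O)c2c1`: 184000 nM
Compound 2 `COc1ccc(-c2cc(=O)c3cc(NC(C)=O)ccc3o2)cc1`: 226000 nM
Compound 3 `CC(=O)Nc1ccc2oc(-c3ccc(C(F)(F)F)cc3)cc(=O)c2c1`: 330000 nM

Compound 2 stands second highest of these three numbers in this assay. Its nearest neighbour is compound 1, with a 1.2-fold higher number from compound 1 to compound 2 (0.09 log units; within the scatter), and its furthest is compound 3, with a 1.5-fold higher number from compound 2 to compound 3 (0.16 log units; within the scatter). The remaining pair shows a 1.8-fold higher number from compound 1 to compound 3 (0.25 log units; within the scatter). All three steps concern substituents on an aromatic carbon of the phenyl ring, and none of them reaches beyond the scatter.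

Compound 4 `COc1ccc(-c2cc(=O)c3cc(N)ccc3o2)cc1` differs from compound 2 in one place: hydrogen in place of acetyl on a nitrogen on an aromatic ring. Going by the values given here, no measured step touches the acetamido group, so none of the three steps bears directly on this change. What the measured steps do show is that, within this series, swapping hydrogen, methoxy and trifluoromethyl on the phenyl ring left the number in this assay essentially unchanged. On that basis the account expects no step beyond the scatter from compound 2 to compound 4 in this assay, that is, an expected step of a 1.1-fold lower number from compound 2 to compound 4 (0.05 log units; within the scatter). Compound 4 is therefore estimated at 200000 nM, with a range from 90000 nM to 450000 nM, before its own measurement is considered.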

Compound 4, half-maximal cytotoxic concentration: 241000 nM
Beside the measured number, compound 4's estimate is 1.2-fold (0.08 log units) below it; the range from low to high includes it.
By their numbers in this assay, from the lowest: compounds 1, 2, 4 and 3 (each within the scatter of the next).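

In this assay, going by these compounds alone, the first change at the acetamido group gives a 1.1-fold higher number from compound 2 to compound 4 (0.03 log units; within the scatter) and so, with acetyl replaced by hydrogen on the nitrogen, the number stays within the scatter. The earlier compounds shown here varied only the substituent on the phenyl ring, whereas this pair shows that going from acetamido to amino, at a second place on the molecule, also leaves the number in this assay unresolved from that of its partner, at least with methoxy on the phenyl ring. Nothing given here offers an explanation for this result.

The compounds shown leave open whether the same change from acetamido to amino would read the same way with hydrogen or trifluoromethyl on the phenyl ring, since this single pair carries methoxy there. Within the data shown here, they also leave open whether a larger change on that nitrogen, such as a longer acyl chain, a dimethylamino group or a substituent bearing a carboxylic acid, would still stay within the scatter in this assay or would produce the first step beyond it.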